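A few compounds are considered here, and "the series" means these few. Any claim that something is new, unique, unknown or untested is made for them only; others in the source may bear on it.

Of the compounds shown here, three sharing one core have so far been tested in an ADME assay on KB cells (Homo sapiens) for cytotoxicity, read by MTT assay, with a stated time of 72 h; on this read-out higher numbers stand for lower toxicity in this test and lower numbers for higher toxicity in this test. Compound 1 (`COc1ccc(Nc2nc(-c3ccccn3)cs2)cc1`) gives 140000 nM there. Compound 2 (`c1ccc(-c2csc(Nc3ccc4c(c3)OCCO4)n2)nc1`) gives 55600 nM on the same scale, and compound 3 (`COc1cccc(Nc2nc(-c3ccccn3)cs2)c1`) gives 51200 nM in the same test, so these two cannot be told apart within the usual scatter of repeated measurements. Compound 3 thus shares the low end of the three numbers with compound 2, while compound 1 lies higher, beyond the scatter.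

Compound 4 (`COc1ccc(Nc2nc(-c3ccccn3)cs2)cc1OC`) has not been measured yet. It differs from compound 3 by methoxy in place of hydrogen on an aromatic carbon, which is methoxy in place of hydrogen on an aromatic carbon, ortho to a methoxy group and para to a large group. Among the compounds with values here, no measured pair shows this change on its own, so any forecast is rough. The two compounds that carry a single methoxy, compound 3 at 51200 nM and compound 1 at 140000 nM, offer the nearest guide, and compound 4 is expected to fall around or between them. The estimated move, a 1.3-fold higher number from compound 3 to compound 4 (0.10 log units; within the scatter), is small, towards a higher number, and may well stay within the scatter. The expected value for compound 4 is 65000 nM within an estimated range of 28000 nM to 150000 nM for the coming measurement.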

Compound 4, half-maximal cytotoxic concentration: 62000 nM
For compound 4 the middle estimate is 1.0-fold (0.02 log units) above the measured one; low and high end bracket the measured number.
By their numbers in this assay, from the lowest: compounds 3, 2 and 4 (each within the scatter of the next); then compound 1.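

In this assay, methoxy in place of hydrogen on an aromatic carbon, ortho to a methoxy group and para to a large group, gives a 1.2-fold higher number from compound 3 to compound 4 (0.08 log units; within the scatter), so on compound 3 this added group leaves the read-out indistinguishable from its starting value. The same kind of swap starting from the other single-methoxy compound gives a 2.3-fold lower number from compound 1 to compound 4 (0.35 log units; beyond the scatter), a modest step towards higher toxicity in this test, so adding a methoxy does not have the same outcome on both compounds: here the result goes with where the first methoxy already stands. No measurement of any other property is available to account for this difference, so the pair records the outcome without explaining it.

All the groups shown on this ring so far are oxygen-linked, so it remains open whether a fluorine, a hydroxyl or an amine at this position would stay within the scatter of compound 3 or move the number clearly. Going by these compounds, it is also open whether a longer chain on the oxygen, such as ethoxy, would change the read-out any more than methoxy does.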